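Fluoro Substitution on a Phenyl-Indole Series: Predicting Compound 4

This account rests on a few compounds, and the source may have more. Where it says the series, first, only, none or still open, it means among the compounds named here.

Of the compounds shown here, three sharing an acetyl-bearing indole core have been tested in a functional assay on MCF7 cells (Homo sapiens) for cytotoxicity, read by MTT assay, with a stated time of 2 days, tested at 1 uM; on this read-out lower numbers stand for a stronger effect and higher numbers for a weaker effect at the one concentration tested. Compound 1 `COc1ccc(-c2cc(C(C)=O)c3[nH]c(-c4ccccc4)cc3c2)cc1` gives 88.8% in this assay. Compound 2 `COc1ccc(-c2cc(C(C)=O)c3[nH]c(-c4ccc(F)cc4)cc3c2)cc1` differs from compound 1 by fluoro in place of hydrogen on an aromatic carbon, and in this assay compound 2 gives 69.7%; the step is a number 19.1 percentage points lower from compound 1 to compound 2 (beyond the scatter). Compound 3 `CC(=O)c1cc(/C=C/c2ccccc2)cc2cc(-c3ccccc3)[nH]c12` differs from compound 1 by 2-phenylethenyl in place of 4-methoxyphenyl on an aromatic carbon, and in this assay compound 3 gives 93.4%, a step of a number 4.6 percentage points higher from compound 1 to compound 3 (within the scatter), so compounds 1 and 3 cannot be told apart on this read-out.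

Compound 4 `CC(=O)c1cc(/C=C/c2ccccc2)cc2cc(-c3ccc(F)cc3)[nH]c12` has not yet been measured. It differs from compound 3 by fluoro in place of hydrogen on an aromatic carbon, and this is the same change that separates compound 1 from compound 2, with the place described in identical words in both pairs. Because a number 19.1 percentage points lower from compound 1 to compound 2 (beyond the scatter), the same change on the core of compound 3 is expected to lower the number by a comparable, modest amount, though the step from compound 1 to compound 3 has already shown that the two cores respond alike to a change elsewhere, so the size of the step is taken from the single precedent with some allowance for scatter. The expected step is a number 17.4 percentage points lower from compound 3 to compound 4 (beyond the scatter). Compound 4 is therefore estimated to give 76% in this assay, with a range from 60% to 92%.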

Compound 4, a percentage reported as activity, at one concentration (the size of the read-out at that concentration, not a potency): 86.9%
Compound 4: middle estimate off by 10.9 percentage points, on the low side, within the range that was stated.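

In this assay, the change from phenyl to 4-fluorophenyl on the core of compound 3 gives a number 6.5 percentage points lower from compound 3 to compound 4 (within the scatter), and the gap between this step and the earlier one does not separate the two cores: the same change on two cores in this assay, a number 19.1 percentage points lower (beyond the scatter) from compound 1 to compound 2 and a number 6.5 percentage points lower (within the scatter) from compound 3 to compound 4, 12.6 percentage points apart, within the scatter of two such steps. The exchange of 4-methoxyphenyl for 2-phenylethenyl, read on the fluoro-bearing pair, gives a number 17.2 percentage points higher from compound 2 to compound 4 (beyond the scatter), and it too stays in line with its earlier counterpart: the same change on two cores in this assay, a number 4.6 percentage points higher (within the scatter) from compound 1 to compound 3 and a number 17.2 percentage points higher (beyond the scatter) from compound 2 to compound 4, 12.6 percentage points apart, within the scatter of two such steps. This shows that the fluoro step is compatible with carrying over from one core to the other, yet it does not show that the step keeps a fixed size, since one of the two steps lies beyond the scatter and the other within it, and two pairs can neither establish transfer across the series nor prove that the core alters the step.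

The compounds shown leave open how chloro, an amine or a carboxylic acid would read in this assay if placed where fluoro stands on the phenyl ring. They also leave open whether the fluoro step would hold on a core in which the acetyl group gives way to another group, such as an amide or a longer alkyl chain.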